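A few compounds are considered here, and "the series" means these few. Any claim that something is new, unique, unknown or untested is made for them only; others in the source may bear on it.

Three compounds share one core and differ only in the ester at the end of the acrylate chain. Compound 2 `CCOC(=O)/C=C/c1ccc(NC(=O)C2(NC(=O)c3ccc4c(C5CCCC5)c(-c5ncc(Cl)cn5)n(C)c4c3)CCC2)cc1OCC` gives 3.07 h in an ADME assay (liver) for pharmacokinetics, with Liver microsome (Rattus norvegicus) as the target, using microsomes (a lower number here means that the compound disappears faster, a higher number that the compound lasts longer), the highest of the three values. Compound 3 `CCCOC(=O)/C=C/c1ccc(NC(=O)C2(NC(=O)c3ccc4c(C5CCCC5)c(-c5ncc(Cl)cn5)n(C)c4c3)CCC2)cc1OCC` gives 0.35 h, and compound 1 `CCOc1cc(NC(=O)C2(NC(=O)c3ccc4c(C5CCCC5)c(-c5ncc(Cl)cn5)n(C)c4c3)CCC2)ccc1/C=C/C(=O)OCOP(=O)(O)O` gives 0.15 h. The step of an 8.8-fold lower number from compound 2 to compound 3 (0.94 log units; beyond the scatter) and the step of a 20-fold higher number from compound 1 to compound 2 (1.31 log units; beyond the scatter) both show that any change at this ester carbon away from compound 2 has so far gone with a lower number.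

Compound 4 `CCOc1cc(NC(=O)C2(NC(=O)c3ccc4c(C5CCCC5)c(-c5ncc(Cl)cn5)n(C)c4c3)CCC2)ccc1/C=C/C(=O)OCC(=O)OC` has not yet been measured in this assay. It differs from compound 2 in one place: methoxycarbonyl in place of methyl on a saturated chain carbon bound to an oxygen next to a carbonyl group. Within the data shown here, two measured steps bear on this. From compound 2 to compound 3, one extra carbon on the ester chain gave an 8.8-fold lower number from compound 2 to compound 3 (0.94 log units; beyond the scatter); from compound 1 to compound 2, removal of a larger group at the same carbon gave a 20-fold higher number from compound 1 to compound 2 (1.31 log units; beyond the scatter). Both point the same way: compound 2 holds the best number, and the entering group in compound 4 is larger than the methyl it replaces. Compound 4 is therefore expected to give a lower number, a step of about a 7.7-fold lower number from compound 2 to compound 4 (0.89 log units; beyond the scatter), with an estimated half-life near 0.4 h and a likely range between 0.12 h and 1.3 h.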

Compound 4, half-life: 2.08 h
For compound 4 the middle estimate is 5.2-fold (0.72 log units) below the measured one; the measured number lies above the stated range.
By their numbers in this assay, from the lowest: compound 1; then compound 3; then compounds 4 and 2 (each within the scatter of the next).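

In this assay, methoxycarbonyl in place of methyl on the saturated chain carbon bound to an oxygen next to a carbonyl group gave a 1.5-fold lower number from compound 2 to compound 4 (0.17 log units; within the scatter), so compound 2 no longer stands alone at the top of this short series, and a group with more heavy atoms at this carbon does not by itself go with a lower number. Ethyl, the smaller of the two groups compared in the next step, stands on the low side of a 5.9-fold higher number from compound 3 to compound 4 (0.77 log units; beyond the scatter), so among these compounds the number of heavy atoms in the group does not set the order, and compound 3 goes against any reading based on size alone. The phosphorus-bearing group of compound 1 remains on the low side of a 14-fold higher number from compound 1 to compound 4 (1.14 log units; beyond the scatter), which shows that the low number of compound 1 is not shared by every larger group at this carbon.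

From the compounds shown here alone, whether a carboxylic acid or an amine in place of methoxycarbonyl at this carbon, or a longer chain carrying the methoxycarbonyl, would give a number like that of compound 4 stays open. Nothing shown here offers an explanation for these differences in half-life.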